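The source may hold more compounds than are shown below. What is called first, only, known or untested is meant among the compounds shown, and "the series" means these compounds.

Measured compounds: compound 2, `O=C(CCCCCCc1ccccc1)c1nc(-c2ccccc2)co1`, 65 nM; compound 1, `O=C(CCCCCCc1ccccc1)c1nc(C(=O)C(F)(F)F)co1`, 470 nM.

Compound 2 gives the lower of the two numbers in an assay on isolated protein for inhibition of Fatty-acid amide hydrolase 1 (Rattus norvegicus); on this read-out higher numbers stand for weaker inhibition and lower numbers for stronger inhibition; its nearest neighbour is compound 1, reached by a 7.2-fold lower number from compound 1 to compound 2 (0.86 log units; beyond the scatter), which corresponds to the change from a (trifluoromethyl)carbonyl group to a phenyl group on the shared core.

Compound 3, `CNC(=O)c1coc(C(=O)CCCCCCc2ccccc2)n1`, is not yet measured. Its structure differs from compound 2 by methylcarbamoyl in place of phenyl on an aromatic carbon. Among the compounds with values here, only the step from compound 1 to compound 2 bears on this position, and it shows that exchanging the group on this aromatic carbon moves the number by a modest amount. Methylcarbamoyl is neither of the two groups already seen, so the direction is uncertain; a step of similar size to the one seen, in either direction, is plausible. Compound 3 is expected to give 80 nM in this assay, within a range of 15 nM to 400 nM, corresponding to an expected step of a 1.2-fold higher number from compound 2 to compound 3 (0.09 log units; within the scatter).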

Compound 3, inhibition constant: 1.8 nM
Compound 3: the middle estimate sits 44-fold (1.65 log units) above what was measured, and the stated range ends above it.
By their numbers in this assay, from the lowest: compound 3; then compound 2; then compound 1.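

In this assay, within the data shown here, this aromatic carbon tolerates far more change than the earlier pair suggested: methylcarbamoyl in place of phenyl gives a 36-fold lower number from compound 2 to compound 3 (1.56 log units; beyond the scatter) and is a large step, whereas the only earlier step was modest. Changing trifluoromethyl to methylamino on the carbonyl carbon gives a 260-fold lower number from compound 1 to compound 3 (2.42 log units; beyond the scatter) and places two carbonyl-bearing groups at opposite ends of the three compounds. A carbonyl on this carbon therefore does not set the number by itself, and phenyl, which has none, falls between them.

Still open, from the compounds shown here alone, is how the number responds to the amide hydrogen and the methyl, which a dimethylcarbamoyl group, an unsubstituted carbamoyl group or a carboxylic acid on this carbon would test. No evidence at hand accounts for the size of these steps.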